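Four-position swap on the chlorobenzyloxy coumarin series

The compounds below may be only part of what the source reports. "The series", "measured", "known", "first", "only" and "open" are said of these compounds alone.

Compound 3 `O=c1cc(Oc2ccccc2)c2ccc(OCc3cccc(Cl)c3)cc2o1` gives 4070 nM in an assay on isolated protein (strain Sprague-Dawley) for inhibition of Amine oxidase [flavin-containing] B (Rattus norvegicus), read by spectrophotometry, with a stated time of 5 min (on this read-out higher numbers stand for weaker inhibition and lower numbers for stronger inhibition), the second highest of the three numbers: compound 1 `COCOc1cc(=O)oc2cc(OCc3cccc(Cl)c3)ccc12` gives 100 nM and compound 2 `O=C(COc1cc(=O)oc2cc(OCc3cccc(Cl)c3)ccc12)N1CCCCC1` gives 38900 nM. Compound 4 `Nc1cc(=O)oc2cc(OCc3cccc(Cl)c3)ccc12` differs from compound 3 by amino in place of phenoxy on an aromatic carbon. Among the compounds with values here, no measured step replaces a group at this carbon with amino, so the bearing is indirect. The steps of a 41-fold higher number from compound 1 to compound 3 (1.61 log units; beyond the scatter) and a 9.6-fold lower number from compound 2 to compound 3 (0.98 log units; beyond the scatter) show that this position moves this assay strongly, and the smaller group of compound 1 gave the lowest number. A step toward a lower number is therefore expected for compound 4, of roughly the size a 16-fold lower number from compound 3 to compound 4 (1.21 log units; beyond the scatter), with wide uncertainty. Compound 4 is estimated at 250 nM, range 25 nM to 2500 nM.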

Compound 4, half-maximal inhibitory concentration: 47.9 nM
Beside the measured number, compound 4's estimate is 5.2-fold (0.72 log units) above it; the range from low to high includes it.
By their numbers in this assay, from the lowest: compound 4; then compound 1; then compound 3; then compound 2.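

Amino needs no oxygen link to this aromatic carbon and gives the lowest number of the four in this assay, with an 85-fold lower number from compound 3 to compound 4 (1.93 log units; beyond the scatter) and an 810-fold lower number from compound 2 to compound 4 (2.91 log units; beyond the scatter), but only a 2.1-fold lower number from compound 1 to compound 4 (0.32 log units; beyond the scatter). Within the data shown here, the numbers now rise from amino through methoxymethoxy and phenoxy to ((piperidin-1-yl)carbonyl)methoxy, following group size at this carbon, with no compound against it. Nothing available here explains this order.

Open, on these data alone, is whether the nitrogen or the small size of the group carries the result. Methoxy, methylamino and dimethylamino at this carbon would separate the two.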